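This account rests on a few compounds, and the source may have more. Where it says the series, first, only, none or still open, it means among the compounds named here.

Compound 1 `Cc1cc(O)c(C2=NN(c3ccc(S(N)(=O)=O)cc3)C(c3ccccc3Cl)C2)cc1Cl`: in a functional assay on CCRF-CEM cells (Homo sapiens) for antiproliferative activity, with a stated time of 48 h (a lower number here means that less compound is tolerated, a higher number that more compound is tolerated), compound 1 gives > 100000 nM, which is a limit of the assay and not a number.
Compound 2 `COc1ccc(C2CC(c3cc(Cl)c(C)cc3O)=NN2c2ccc(S(N)(=O)=O)cc2)cc1OC`: in this assay compound 2 gives > 100000 nM, likewise a limit and not a number.

For the measured compounds named here, compound 2 therefore stands at a limit in this assay, and the one further value shown is a limit as well, so nothing places compound 2 within a measured range. The step that the two limits leave unreadable from compound 1 to compound 2 cannot be given a size because of the limit of > 100000 nM in this assay, at which 2 of the 2 values shown sit.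

Compound 3 `COc1ccc(C2CC(c3cc(Cl)c(C)cc3O)=NN2c2ccc(S(N)(=O)=O)cc2)c(OC)c1OC` differs from compound 2 by methoxy in place of hydrogen on an aromatic carbon; cut one bond further out, the change reads 3,4-dimethoxyphenyl to 2,3,4-trimethoxyphenyl. Going by the values given here, the only measured step, which is unreadable in size, does not show a direction for this change, and no other measured pair speaks to it. With both shown values at the limit of this assay, no step beyond the scatter can be expected, and a further limit is the most likely outcome.

Compound 3 is expected at 150000 nM, with a range from 50000 nM to 500000 nM. The expected step is a step that the limit leaves unreadable from compound 2 to compound 3.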

Compound 3, concentration lethal to 50% of the cells: > 100000 nM
Compound 3: only a limit was reported; the forecaster's own chance of this, stated with the estimate: 85%; the middle value lies beyond the limit too.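

In this assay compound 3 gives > 100000 nM, again a limit and not a number. No step among compound 1, compound 2 and compound 3 can be read in size, because all three stand at the same point: the limit of > 100000 nM in this assay, at which 3 of the 3 values shown sit.

The compounds shown leave open whether 2-chlorophenyl, 3,4-dimethoxyphenyl and 2,3,4-trimethoxyphenyl differ at all in this assay.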